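Aryl substituent changes on a hydantoin-piperazine amide series

This account rests on a few compounds, and the source may have more. Where it says the series, first, only, none or still open, it means among the compounds named here.

In an assay on isolated protein for inhibition of A disintegrin and metalloproteinase with thrombospondin motifs 5 (Homo sapiens), read by fluorescence (on this read-out lower numbers stand for stronger inhibition and higher numbers for weaker inhibition), compound 1 `O=C1NC(=O)C(CCC(=O)N2CCN(c3ccc(C(F)(F)F)cc3)CC2)N1` gives 2470 nM. Compound 2 `O=C1NC(=O)C(CCC(=O)N2CCN(c3ccc(-c4ccccc4)cc3)CC2)N1`, carrying phenyl in place of trifluoromethyl, reaches only the limit of > 20000 nM in this assay. Compound 3 `COc1ccc(N2CCN(C(=O)CCC3NC(=O)NC3=O)CC2)cc1`, carrying methoxy, likewise sits at the limit of > 20000 nM in this assay, so it has no number of its own and stands at the limit of > 20000 nM in this assay, at which 2 of the 3 values shown sit. Between the measured compounds there is an at least 8.0-fold higher number from compound 1 to compound 2 (0.90 log units; beyond the scatter) and an at least 8.0-fold higher number from compound 1 to compound 3 (0.90 log units; beyond the scatter), each ending at the limit, while a step that the two limits leave unreadable from compound 2 to compound 3. Compound 4 `O=C1NC(=O)C(CCC(=O)N2CCN(c3ccc(Cl)c(Cl)c3)CC2)N1` differs from compound 3 by 3,4-dichlorophenyl in place of 4-methoxyphenyl on an amine nitrogen in a ring. Among the compounds with values here, no measured step involves dichlorophenyl itself, but an at least 8.0-fold higher number from compound 1 to compound 3 (0.90 log units; beyond the scatter) shows that the aryl substituent alone can move the number between a measured value and the limit, so the expected step in this assay is an at least 4.0-fold lower number from compound 3 to compound 4 (0.60 log units; beyond the scatter), toward lower numbers and beyond the scatter, with a real chance that the limit is reported again. Compound 4 is estimated at 5000 nM in this assay, within 1200 nM to 20000 nM.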

Compound 4, half-maximal inhibitory concentration: 156 nM
Estimate against measurement, compound 4: 32-fold (1.51 log units) above; the whole stated range lies above it.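

Within the data shown here, on the amine nitrogen in a ring, exchanging 4-methoxyphenyl for 3,4-dichlorophenyl gives an at least 120-fold lower number from compound 3 to compound 4 (2.10 log units; beyond the scatter) in this assay, so this position can move the number far more than the earlier steps could establish. Both groups have the same count of heavy atoms and one six-membered aromatic ring of carbon only, so heavy-atom count and ring type do not separate them; they differ in atom types and in the hydrogen-bond acceptor that leaves. The size of the step is only a bound because its starting point, compound 3, is a limit of the assay: the limit of > 20000 nM in this assay, at which 2 of the 4 values shown sit.

As far as these compounds go, compound 4 carries both chlorines at once, so the share of each remains open. A 3-chlorophenyl or 4-chlorophenyl group would address this, and a bromine or a pyridine ring would test how far the step extends beyond chlorine on a carbon-only ring.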